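This account rests on a few compounds, and the source may have more. Where it says the series, first, only, none or still open, it means among the compounds named here.

Measured so far in a functional assay on OVCAR-8 cells (Homo sapiens) for antiproliferative activity; on this read-out higher numbers stand for weaker inhibition and lower numbers for stronger inhibition:

compound 1, `CC(=O)OCC[C@@H]1C[C@@H](c2ccc(F)c(F)c2)[C@H](NC(=O)c2cc(-c3c(Cl)cnn3C)c(Cl)o2)CN1`, gives 4960 nM
compound 2, `C=CC[C@@H]1C[C@@H](c2ccc(Cl)c(Cl)c2)[C@H](NC(=O)c2cc(-c3c(Cl)cnn3C)c(Cl)o2)CN1`, gives 990 nM
compound 3, `Cn1ncc(Cl)c1-c1cc(C(=O)N[C@@H]2CN[C@H](CC(N)=O)C[C@H]2c2ccc(Cl)c(Cl)c2)oc1Cl`, gives 1000 nM

Compound 3 stands second highest of the three numbers. Its nearest neighbour is compound 2: the step of a 1.0-fold higher number from compound 2 to compound 3 (0.00 log units; within the scatter) lies within the scatter, so the two compounds cannot be ordered on this read-out. Within the data shown here, compound 1 gives the higher number of the set, but it differs from compound 3 in more than one place, so no single step connects the two and only the two values themselves can be compared.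

Compound 4, `CN(C)CC[C@@H]1C[C@@H](c2ccc(Cl)c(Cl)c2)[C@H](NC(=O)c2cc(-c3c(Cl)cnn3C)c(Cl)o2)CN1`, differs from compound 3 in one place: (dimethylamino)methyl in place of carbamoyl on a saturated chain carbon bound to a saturated ring carbon

Among the measured compounds shown here, the one measured step at this place is a 1.0-fold higher number from compound 2 to compound 3 (0.00 log units; within the scatter), which was flat. For the measured compounds named here, no measured step involves a (dimethylamino)methyl group, so the data give no direct guide to this change. The expectation is therefore a step of no size beyond the scatter, a 1.3-fold lower number from compound 3 to compound 4 (0.10 log units; within the scatter). Compound 4 is estimated at 800 nM, with a range from 250 nM to 2500 nM.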

Compound 4, half-maximal inhibitory concentration: 1510 nM
Beside the measured number, compound 4's estimate is 1.9-fold (0.28 log units) below it; the measured number falls inside the stated range.
By their numbers in this assay, from the lowest: compounds 2, 3 and 4 (each within the scatter of the next); then compound 1.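

In this assay, a third type of group at this place, on a saturated chain carbon bound to a saturated ring carbon, leaves compounds that still cannot be ordered: (dimethylamino)methyl in place of carbamoyl gives (a 1.5-fold higher number from compound 3 to compound 4 (0.18 log units; within the scatter)), and (dimethylamino)methyl in place of vinyl gives (a 1.5-fold higher number from compound 2 to compound 4 (0.18 log units; within the scatter)). The change from carbamoyl removes its 1 hydrogen-bond donor and its double bond outside aromatic rings, yet the step stays within the scatter, so neither feature is required at this place on this read-out for compounds 2, 3 and 4. No measured evidence here bears on why these groups read alike.

From the compounds shown here alone, whether a carboxylic acid, a primary amine or a longer chain at this place would separate from compounds 2, 3 and 4 remains open. Compound 1 differs from each of them in more than one place, so its acetate-bearing chain cannot be judged separately.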